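Trifluoromethoxy for trifluoromethyl on two cores

This account rests on a few compounds, and the source may have more. Where it says the series, first, only, none or still open, it means among the compounds named here.

Compound 1 `CC(O)(CSc1ccc(C(F)(F)F)cc1)C(=O)Nc1cccc(S(F)(F)(F)(F)F)c1` and compound 2 `CC(O)(CSc1ccc(OC(F)(F)F)cc1)C(=O)Nc1cccc(S(F)(F)(F)(F)F)c1` share one core; compound 3 `CC(O)(COc1ccccc1C(F)(F)F)C(=O)Nc1ccc(S(F)(F)(F)(F)F)cc1` and compound 4 `CC(O)(COc1ccccc1OC(F)(F)F)C(=O)Nc1ccc(S(F)(F)(F)(F)F)cc1` share another, and the difference between the two cores is not broken down here. In a functional assay on VCaP cells (Homo sapiens) for antiproliferative activity, read by propidium iodide staining, with a stated time of 96 h (a higher number here means a weaker inhibitor, a lower number a stronger inhibitor), compound 1 gives 27300 nM and compound 2 gives 28500 nM. The change between them is trifluoromethoxy in place of trifluoromethyl on an aromatic carbon and it made a step of a 1.0-fold higher number from compound 1 to compound 2 (0.02 log units; within the scatter). In this assay compound 3 gives 3100 nM, the lowest of the three numbers. The change from compound 3 to compound 4 is trifluoromethoxy in place of trifluoromethyl on an aromatic carbon. It is the same kind of change as that from compound 1 to compound 2, but not the same: the place is ortho to a large group here and para to a large group there. For the measured compounds named here, only one measured instance of this change is available. The expectation for compound 4 rests on compound 1 and compound 2, whose step a 1.0-fold higher number from compound 1 to compound 2 (0.02 log units; within the scatter) lay within the scatter. Compound 4 is therefore expected to show a step of a 1.1-fold higher number from compound 3 to compound 4 (0.03 log units; within the scatter). In this assay compound 4 is estimated at 3300 nM, between 1500 nM and 7500 nM.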

Compound 4, half-maximal inhibitory concentration: 9700 nM
For compound 4 the middle estimate is 2.9-fold (0.47 log units) below the measured one; measured number above the stated range.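

In this assay, trifluoromethoxy in place of trifluoromethyl did not carry over from one core to the other with the same effect: the same change on two cores in this assay, a 1.0-fold higher number (0.02 log units; within the scatter) from compound 1 to compound 2 and a 3.1-fold higher number (0.50 log units; beyond the scatter) from compound 3 to compound 4, 3.0-fold (0.48 log units) apart, beyond the scatter of two such steps. On the core of compound 3 the change gave a 3.1-fold higher number from compound 3 to compound 4 (0.50 log units; beyond the scatter), so the flat step on the core of compound 1 is a poor guide to the outcome on the core of compound 3. This does not show which feature of the two cores accounts for the gap, since each core offers a single pair, the cores differ in more than one place, and the site of the change is not the same in the two pairs.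

Open, going by these compounds, is how a nitrile or a methoxy group on the same aromatic carbon, ortho to a large group, would compare with compound 3. Also open, on these data alone, is whether a third core would follow the step seen on the core of compound 1 or the one seen on the core of compound 3.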